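Aryl Swap on the Core: Acid Dissociation Expected Unchanged

A few compounds are considered here, and "the series" means these few. Any claim that something is new, unique, unknown or untested is made for them only; others in the source may bear on it.

Measured so far in a physicochemical assay for acid dissociation:
compound 1 `COc1ccc(F)cc1CNCCCNc1ccnc2cc(Cc3ccc(C#N)cc3)ccc12` gives 9.47
compound 2 `CC(C)(C)c1ccc(-c2ccc3c(NCCCNCc4ccco4)ccnc3c2)cc1` gives 9.47
compound 3 `COc1cccc(CNCCCNc2ccnc3cc(Cc4ccc(C#N)cc4)ccc23)c1O` gives 9.47

Compound 1 stands level with compounds 2 and 3 at the digits shown. Among the compounds with values here, the one measured step that touches it, no change at the digits printed from compound 1 to compound 3 (within the scatter), alters the group on the chain carbon bound to the amine nitrogen and stays within the scatter. Compound 2 carries a different group on the shared core and still reads the same as compound 1.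

Compound 4 `COc1ccc(F)cc1CNCCCNc1ccnc2cc(-c3ccc(C(F)(F)F)cc3)ccc12` differs from compound 1 in one place: 4-(trifluoromethyl)phenyl in place of 4-cyanobenzyl on an aromatic carbon. Within the data shown here, no measured step changes this position directly, but compounds 1 and 2 show that unlike groups on the core go with the same value. Compound 4 is therefore expected to sit at 9.47, between 9.1 and 9.8, a step of no change at the digits printed from compound 1 to compound 4 (within the scatter) that is expected to stay within the scatter.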

Compound 4, acid dissociation constant: 9.47
The estimate for compound 4 equals the measured number at the digits printed; the range from low to high includes it.
By their numbers in this assay, from the lowest: compounds 1, 2, 3 and 4 (each within the scatter of the next).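

In this assay, within the data shown here, 4-(trifluoromethyl)phenyl in place of 4-cyanobenzyl on an aromatic carbon of the shared core gives no change at the digits printed from compound 1 to compound 4 (within the scatter), the only measured step at this position. The entering group has no hydrogen-bond acceptor and no triple bond, while the leaving group has one of each, and the two values still lie within the scatter. Nothing available explains this result. As far as these compounds go, whether a carboxylic acid or an amine on this aromatic carbon would also stay within the scatter remains open.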